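Extending the chain of compound 3 toward a carboxylic acid

This account rests on a few compounds, and the source may have more. Where it says the series, first, only, none or still open, it means among the compounds named here.

Measured compounds:
- compound 1: `CCc1onc(NS(=O)(=O)c2ccc(C(C)(C)C)cc2)c1Sc1cccc(OC)c1`, 2800 nM
- compound 2: `COc1cccc(Sc2c(NS(=O)(=O)c3ccc(C(C)(C)C)cc3)noc2CCCC#N)c1`, 520 nM
- compound 3: `COc1cccc(Sc2c(NS(=O)(=O)c3ccc(C(C)(C)C)cc3)noc2C)c1`, 300 nM

In an assay on COS-7 cells for displacement of a labelled ligand from Endothelin receptor type B (Sus scrofa) (a lower number here means a stronger inhibitor, a higher number a weaker inhibitor), compound 3 gives the lowest of the three numbers. Its nearest neighbour is compound 2, whose number lies within the scatter of it, so the two cannot be ordered; compound 1 stands furthest away, and the step of a 9.3-fold lower number from compound 1 to compound 3 (0.97 log units; beyond the scatter) lies beyond the scatter. Compound 4, `COc1cccc(Sc2c(NS(=O)(=O)c3ccc(C(C)(C)C)cc3)noc2CCCC(=O)O)c1`, differs from compound 3 by 2-carboxyethyl in place of hydrogen on a saturated chain carbon bound to an aromatic carbon.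

Among the measured compounds shown here, two measured steps bear on this change. The step of a 1.7-fold lower number from compound 2 to compound 3 (0.24 log units; within the scatter) shows that a chain bearing a nitrile at this carbon leaves the number within the scatter of the bare methyl. The step of a 9.3-fold lower number from compound 1 to compound 3 (0.97 log units; beyond the scatter) shows that a longer plain chain at the same carbon costs a modest amount. For the measured compounds named here, a carboxylic acid at the end of such a chain has no measured precedent in this set, so the acid itself is an unknown.

Weighing compound 2 most heavily, the author expects a small step in this assay, toward a somewhat higher number, of about a 1.5-fold higher number from compound 3 to compound 4 (0.18 log units; within the scatter). For compound 4 the estimate is 450 nM, with a range of 150 nM to 1500 nM.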

Compound 4, half-maximal inhibitory concentration: 500 nM
Compound 4: middle estimate off by 1.1-fold (0.05 log units), on the low side; low and high end bracket the measured number.
By their numbers in this assay, from the lowest: compounds 3, 4 and 2 (each within the scatter of the next); then compound 1.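

In this assay, the position proves open to a chain ending in a carboxylic acid: with a 1.7-fold higher number from compound 3 to compound 4 (0.22 log units; within the scatter), methyl and 3-carboxypropyl cannot be ordered, and with a 1.0-fold lower number from compound 2 to compound 4 (0.02 log units; within the scatter), the acid and the nitrile at the end of the chain cannot be told apart either. The plain ethyl chain of compound 1 remains the outlier, as a 5.6-fold lower number from compound 1 to compound 4 (0.75 log units; beyond the scatter) lies beyond the scatter, so across these four compounds the number does not simply rise with chain length: compound 2 and compound 4 carry longer chains than compound 1, yet both give lower numbers than it does. The data shown offer no independent measurement that could account for this behaviour at the position.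

From the compounds shown here alone, whether an amine, an amide or a methyl ester at the end of the same chain would also stay within the scatter of compound 3 remains open. So does the effect of chain length on the acid itself, since neither a carboxymethyl group nor a longer chain ending in a carboxylic acid appears among these compounds, and a plain propyl chain is also absent.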